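A few compounds are considered here, and "the series" means these few. Any claim that something is new, unique, unknown or untested is made for them only; others in the source may bear on it.

Measured in a functional assay on U-87MG ATCC cells (Homo sapiens) for inhibition; a lower number here means a stronger inhibitor, a higher number a weaker inhibitor:
- Compound 1 `COc1cc(/C=C/C(=O)c2cccc(NC(=O)c3cc(Cl)cc(Cl)c3)c2)ccc1O`: > 50 ug/mL, a limit of the assay
- Compound 2 `COc1cc(/C=C/C(=O)c2cccc(NC(=O)C(C)C)c2)ccc1O`: 8.31 ug/mL
- Compound 3 `COC(=O)C(=O)Nc1cccc(C(=O)/C=C/c2ccc(O)c(OC)c2)c1`: 12.2 ug/mL

Compound 3, at 12.2 ug/mL, sits within the scatter of compound 2. Compound 4 `COc1cc(/C=C/C(=O)c2cccc(NC(C)=O)c2)ccc1O` carries methyl in place of methoxycarbonyl on a carbonyl carbon. The closest evidence is a 1.5-fold higher number from compound 2 to compound 3 (0.17 log units; within the scatter), a swap on that same carbonyl carbon that stayed within the scatter. The larger steps, an at least 6.0-fold lower number from compound 1 to compound 2 (0.77 log units; beyond the scatter) and an at least 4.0-fold lower number from compound 1 to compound 3 (0.61 log units; beyond the scatter), both remove 3,5-dichlorophenyl, a group absent from compound 4, so they say little here. No step beyond the scatter is therefore expected in this assay. The estimated change is a 1.2-fold lower number from compound 3 to compound 4 (0.09 log units; within the scatter). For compound 4 the expected value is 10 ug/mL, with an estimated range from 4.5 ug/mL to 22 ug/mL.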

Compound 4, half-maximal inhibitory concentration: > 50 ug/mL
Compound 4 was reported as a limit; the forecaster's own chance of this, stated with the estimate: 5%; at least 5.0-fold (0.69 log units) between middle value and limit.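

Methyl on this carbonyl carbon gives an at least 6.0-fold higher number from compound 2 to compound 4 (0.77 log units; beyond the scatter) and an at least 4.0-fold higher number from compound 3 to compound 4 (0.61 log units; beyond the scatter). So the loss of inhibition no longer belongs to 3,5-dichlorophenyl alone, and this position proves sensitive to a change as simple as a swap to methyl, although the swap between isopropyl and methoxycarbonyl stayed within the scatter. The step between compound 1 and compound 4 cannot be read, because each of the two compounds stands at a limit: the limit of > 50 ug/mL in this assay, at which 2 of the 4 values shown sit.

Going by these compounds, whether an ethyl group, a longer chain or an amine on this carbonyl carbon would keep the inhibition of compound 2 remains open. The compounds shown also leave open how far inhibition falls with methyl.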